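Phenyl in Place of Isobutyl: Expected Solubility Step

The source may hold more compounds than are shown below. What is called first, only, known or untested is meant among the compounds shown, and "the series" means these compounds.

Measured compounds:
compound 1, `c1ccc(-c2ccc3c(NCCCNCc4ccco4)ccnc3c2)cc1`, 32000 nM
compound 2, `COc1cccc(CNCCCNc2ccnc3cc(CC(C)C)ccc23)c1O`, 4200 nM

In a physicochemical assay for solubility, with a stated time of 18 h, at pH 7.4 (on this read-out lower numbers stand for lower solubility and higher numbers for higher solubility), compound 2 gives 4200 nM, the lowest of the two numbers. In this assay, among the compounds with values here, compound 1 gives 32000 nM, a higher number, and the gap between these two values lies beyond the scatter; the two compounds differ in more than one place, so no single step between them can be named.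

Compound 3, `COc1cccc(CNCCCNc2ccnc3cc(-c4ccccc4)ccc23)c1O`, has not yet been measured. It differs from compound 2 by phenyl in place of isobutyl on an aromatic carbon. Compound 1 also carries a phenyl at that place and shows the higher number, but its side chain differs as well, so the comparison is only indirect. For compound 3 a modest rise is expected, the step from compound 2 estimated as a 1.5-fold higher number from compound 2 to compound 3 (0.19 log units; within the scatter), near the edge of the scatter. Compound 3 is therefore estimated at 6500 nM, within a range of 1500 nM to 25000 nM.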

Compound 3, solubility: 32000 nM
Beside the measured number, compound 3's estimate is 4.9-fold (0.69 log units) below it; the measured number lies above the stated range.
By their numbers in this assay, from the lowest: compound 2; then compounds 1 and 3 (each within the scatter of the next).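

In this assay, phenyl in place of isobutyl on an aromatic carbon can now be read as a single change, which compound 1 and compound 2 could not offer, and it gives a 7.6-fold higher number from compound 2 to compound 3 (0.88 log units; beyond the scatter). The read-out therefore responds to the group at this place when the side chain is held constant. With phenyl kept there, 2-hydroxy-3-methoxyphenyl in place of furan-2-yl on a saturated chain carbon bound to an amine nitrogen gives no change at the digits printed from compound 1 to compound 3 (within the scatter), so this pair does not separate the two side-chain end groups. Nothing available bears on what lies behind either step.

From the compounds shown here alone, it remains open whether other groups at this aromatic carbon, such as a methoxy group or an amine, would give a similar number. Also open, going by these compounds, is whether the furan-2-yl side chain would show the same step with isobutyl on the core.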